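The source may hold more compounds than are shown below. What is called first, only, known or untested is meant among the compounds shown, and "the series" means these compounds.

Measured in a functional assay on A-375 cells (Homo sapiens) for cytotoxicity, read by CCK-8 assay, with a stated time of 24 h; a lower number here means a stronger inhibitor, a higher number a weaker inhibitor:
- compound 1 `COc1ccccc1Oc1c(N)nc(-c2ccccc2)nc1OCCO`: > 80000 nM (a limit)
- compound 2 `COc1ccccc1Oc1c(N)nc(-c2cccc(Cl)c2)nc1OCCO`: 30200 nM

For the measured compounds named here, compound 2 holds the only actual number so far, as compound 1 gives only a limit. Compound 3 `COc1ccccc1Oc1c(N)nc(-c2cccc(I)c2)nc1OCCO` departs from compound 2 by iodo in place of chloro on an aromatic carbon. Going by the values given here, the one measured step that bears on this is an at least 2.6-fold lower number from compound 1 to compound 2 (0.42 log units; beyond the scatter), chloro in place of hydrogen on an aromatic carbon. That single step of modest size suggests a further small drop in this assay, close to the scatter. The expected change is a 1.7-fold lower number from compound 2 to compound 3 (0.22 log units; within the scatter). For compound 3 the estimated value is 18000 nM, with an expected range of 7000 nM to 40000 nM.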

Compound 3, half-maximal inhibitory concentration: 1230 nM
For compound 3 the middle estimate is 15-fold (1.17 log units) above the measured one, outside the stated range (below it).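

In this assay, iodo in place of chloro on this ring gives a 25-fold lower number from compound 2 to compound 3 (1.39 log units; beyond the scatter), so the choice of halogen at this position carries a large effect that compounds 1 and 2 could not show. Iodo in place of hydrogen gives an at least 65-fold lower number from compound 1 to compound 3 (1.81 log units; beyond the scatter). That step is only a bound, as compound 1 gives a limit: the limit of > 80000 nM in this assay, at which 1 of the 3 values shown sits.

As far as these compounds go, it remains open whether bromo at this position would fall between chloro and iodo. From the compounds shown here alone, it is also open whether a group without halogen, such as methyl or nitrile, could match compound 3.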